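The source may report more compounds than this note shows. Statements on the series, on what has been measured and on what is new or still open speak of the compounds shown alone.

Compound 2 `Cn1c(=O)n(C2OC(CO)[C@@H](O)[C@H]2O)c2nc(N)nc(O)c21` is the reference point here. Among the measured compounds shown here, in a functional assay on the whole organism (B cells) with Mus musculus as the target (a lower number here means a smaller maximal response, a higher number a larger maximal response), compound 2 gives 99%, the higher of the two numbers measured so far. Compound 1 `CN(C)CCCn1c(=O)n(C2OC(CO)[C@@H](O)[C@H]2O)c2nc(N)nc(O)c21` differs from it in one place, and in this assay compound 1 gives 83%. For the measured compounds named here, the step of a number 16 percentage points higher from compound 1 to compound 2 (beyond the scatter) is the only measured step between these compounds, and it shows the maximal response rising when hydrogen stands in place of 2-(dimethylamino)ethyl on the saturated chain carbon bound to an aromatic nitrogen.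

Compound 3 `Nc1nc(O)c2c(n1)n(C1OC(CO)[C@@H](O)[C@H]1O)c(=O)n2Cc1ccc([N+](=O)[O-])cc1` has not yet been measured. It differs from compound 2 by 4-nitrophenyl in place of hydrogen on a saturated chain carbon bound to an aromatic nitrogen. This change runs the other way from the measured step: a group is added at the same place rather than removed. Going by the values given here, the one comparison available, a number 16 percentage points higher from compound 1 to compound 2 (beyond the scatter), therefore points toward a decrease, and a modest one. For compound 3 the expected step is a number 15 percentage points lower from compound 2 to compound 3 (beyond the scatter). Compound 3 is estimated to give 84% in this assay, with a range from 65% to 100%.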

Compound 3, largest response reached (reported as maximal response), in percent of the reference or control that the assay uses: 147%
Estimate against measurement, compound 3: 63 percentage points below, and the stated range ends below it.
By their numbers in this assay, from the lowest: compound 1; then compound 2; then compound 3.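

In this assay, the place on the saturated chain carbon bound to an aromatic nitrogen turns out to work in both directions: the earlier pair showed only a fall in maximal response with 2-(dimethylamino)ethyl there instead of hydrogen, whereas 4-nitrophenyl in place of hydrogen brings a large rise, a number 48 percentage points higher from compound 2 to compound 3 (beyond the scatter). The identity of the entering group, and not just the presence of a group, therefore goes with the direction of the change in these compounds, and the widest gap so far separates the two groups themselves, a number 64 percentage points higher from compound 1 to compound 3 (beyond the scatter). Nothing available here explains why these two groups move the response in opposite directions.

The compounds shown leave open whether the rise goes with the six-membered aromatic ring alone or also needs the nitro group, a question that a plain benzyl or a 4-aminobenzyl group at this place would help to settle. They also leave open whether the lower value of compound 1 goes with its terminal dimethylamine or with the chain itself, which a plain alkyl chain of the same length would separate.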